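The compounds below may be only part of what the source reports. "The series", "measured", "known", "first", "only" and "open" are said of these compounds alone.

Measured so far in a functional assay on HepG2 cells (Homo sapiens) for inhibition, read by MTT assay, with a stated time of 72 h; a higher number here means a weaker inhibitor, a lower number a stronger inhibitor:
compound 1, `O=c1cc(Cn2cc(CCO)nn2)c2ccc(O)cc2o1`: a limit, > 100000 nM
compound 2, `O=c1cc(Cn2cc(CNS(=O)(=O)c3ccc(Cl)cc3)nn2)c2ccc(O)cc2o1`: 31400 nM
compound 3, `O=c1cc(Cn2cc(CNS(=O)(=O)c3ccc([N+](=O)[O-])cc3)nn2)c2ccc(O)cc2o1`: a limit, > 100000 nM

Compound 1 thus sits at the limit of the limit of > 100000 nM in this assay, at which 2 of the 3 values shown sit, rather than at a number. Compound 4 is `O=c1cc(Cn2cc(CSC(=S)N3CCNCC3)nn2)c2ccc(O)cc2o1`; it differs from compound 1 by a group of 9 heavy atoms (5 carbon, 2 nitrogen, 2 sulfur; one six-membered non-aromatic ring with 2 hetero atoms) in place of a group of 2 heavy atoms (1 carbon, 1 oxygen; no ring), on a saturated chain carbon bound to an aromatic carbon. Going by the values given here, no measured step touches this part of the molecule: the only step, an at least 3.1-fold higher number from compound 2 to compound 3 (0.50 log units; beyond the scatter), alters a substituent on a different part of compound 2 and cannot be carried over. Compound 2, which likewise carries a larger group on the same chain carbon, gives a number where compound 1 gives only a limit. Compound 4 is therefore expected to improve by an at least 2.5-fold lower number from compound 1 to compound 4 (0.39 log units; beyond the scatter) in this assay. The estimate for compound 4 is 40000 nM, with a range from 10000 nM to 150000 nM.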

Compound 4, half-maximal inhibitory concentration: > 100000 nM
Compound 4: only a limit was reported; the forecaster's own chance of this, stated with the estimate: 40%; middle value at least 2.5-fold (0.39 log units) away from the limit.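

In this assay, compound 1 and compound 4 both stand at a limit rather than a number, so no step between them can be read: the limit of > 100000 nM in this assay, at which 3 of the 4 values shown sit.

Going by these compounds, whether the group in compound 4 strengthens or weakens inhibition relative to the hydroxymethyl of compound 1 remains open.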